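Benzyl Exchange and the Expected Cytotoxicity of Compound 4

A few compounds are considered here, and "the series" means these few. Any claim that something is new, unique, unknown or untested is made for them only; others in the source may bear on it.

Compound 1 `Cn1cc(SCc2nnc(SCc3ccccc3Cl)n2-c2c(Cl)cccc2Cl)c2ccccc21` gives 49600 nM in a toxicity assay on HEK-293T cells (Homo sapiens) for cytotoxicity, read by CCK-8 assay, with a stated time of 48 h; on this read-out lower numbers stand for higher toxicity in this test and higher numbers for lower toxicity in this test.
Compound 2 `Cn1cc(SCc2nnc(SCc3ccccc3OC(F)(F)F)n2-c2c(Cl)cccc2Cl)c2ccccc21` reaches only the limit > 100000 nM in this assay, not a number.
Compound 3 `Cn1cc(SCc2nnc(SCc3cccc(Cl)c3Cl)n2-c2c(Cl)cccc2Cl)c2ccccc21` likewise stops at the limit > 100000 nM in this assay.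

Compound 2 therefore stands at the top of what this assay reports, and the same holds for one further compound (the limit of > 100000 nM in this assay, at which 2 of the 3 values shown sit). The step to compound 4 `Cn1cc(SCc2nnc(SCc3cccc(Cl)c3F)n2-c2c(Cl)cccc2Cl)c2ccccc21` is 3-chloro-2-fluorophenyl in place of 2-(trifluoromethoxy)phenyl on a saturated chain carbon bound to a sulfur.

Among the measured compounds shown here, three measured steps bear on this. From compound 1 the read-out moved an at least 2.0-fold higher number from compound 1 to compound 2 (0.30 log units; that floor lies within the scatter), and separately an at least 2.0-fold higher number from compound 1 to compound 3 (0.30 log units; that floor lies within the scatter). Between the two limits the step is a step that the two limits leave unreadable from compound 2 to compound 3. Every measured value sits either at the limit or within a modest distance of it, so the exchange of one benzyl for another has not moved this assay beyond the scatter in any readable direction.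

Compound 4 is therefore expected to show an at least 1.1-fold lower number from compound 2 to compound 4 (0.04 log units; that floor lies within the scatter), that is, no step beyond the scatter. The estimated value of compound 4 in this assay is 90000 nM, with a range from 40000 nM to 200000 nM.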

Compound 4, half-maximal cytotoxic concentration: > 100000 nM
Compound 4 was reported as a limit; the forecaster's own chance of this, stated with the estimate: 55%; middle value at least 1.1-fold (0.04 log units) away from the limit.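

In this assay compound 4 also ends at a limit, > 100000 nM, and not at a number: the limit of > 100000 nM in this assay, at which 3 of the 4 values shown sit. The limit therefore does not depend on the 2-(trifluoromethoxy)phenyl of compound 2, since the 3-chloro-2-fluorophenyl, which carries no oxygen and has fewer heavy atoms, reaches it too on the same saturated chain carbon bound to a sulfur; compound 1 remains the one compound shown with a number. The reading against compound 1 is an at least 2.0-fold higher number from compound 1 to compound 4 (0.30 log units; that floor lies within the scatter), while the steps that join compound 4 to compound 2 and compound 3 cannot be read.

Going by these compounds, how far compound 2, compound 3 and compound 4 lie past the limit stays open. So does whether an amine or a carboxylic acid on the benzyl ring, or a longer chain in place of the benzyl, would bring this read-out to a number.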